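Alkylation of the pyrazole nitrogen in a maleimide series

The source may report more compounds than this note shows. Statements on the series, on what has been measured and on what is new or still open speak of the compounds shown alone.

Measured compounds:
- Compound 1, `Cn1cc(C2=C(c3n[nH]c4ncccc34)C(=O)NC2=O)c2ccccc21`: 62000 nM
- Compound 2, `Cn1cc(C2=C(c3n[nH]c4ncccc34)C(=O)N(c3cccc4ccccc34)C2=O)c2ccccc21`: > 100000 nM

Going by the values given here, in a functional assay on KB cells (Homo sapiens) for antiproliferative activity, read by MTT assay, with a stated time of 48 h (on this read-out lower numbers stand for stronger inhibition and higher numbers for weaker inhibition), compound 1 gives 62000 nM, the only actual number obtained so far. For compound 2 the result is a limit of the assay rather than a number, > 100000 nM, as described by the limit of > 100000 nM in this assay, at which 1 of the 2 values shown sits. The step of an at least 1.6-fold higher number from compound 1 to compound 2 (0.20 log units; that floor lies within the scatter) concerns naphthalen-1-yl in place of hydrogen on an amide-type nitrogen in a ring, and its floor lies within the scatter.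

Compound 3, `Cn1cc(C2=C(c3nn(CCCCn4ccnc4)c4ncccc34)C(=O)NC2=O)c2ccccc21`, is not yet measured. It differs from compound 1 by 4-(1H-imidazol-1-yl)butyl in place of hydrogen on an aromatic nitrogen. Among the compounds with values here, the only measured step sits at a different place in the shared core of compound 1, so no measured step bears on this change, and no direction can be drawn from the data. The expectation is therefore no step beyond the scatter, expressed as a 1.0-fold lower number from compound 1 to compound 3 (0.01 log units; within the scatter). Compound 3 is estimated at 60000 nM in this assay, with a range from 15000 nM to 250000 nM.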

Compound 3, half-maximal inhibitory concentration: > 100000 nM
Compound 3 was reported as a limit; the forecaster's own chance of this, stated with the estimate: 30%; at least 1.6-fold (0.22 log units) between middle value and limit.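

Going by these compounds alone, the aromatic nitrogen of the five-membered aromatic ring, which the earlier compounds left unchanged, now has a step of its own: in this assay there is an at least 1.6-fold higher number from compound 1 to compound 3 (0.20 log units; that floor lies within the scatter) with 4-(1H-imidazol-1-yl)butyl in place of hydrogen. Compound 3 gives > 100000 nM as a limit of the assay and not as a number. This large group on that nitrogen therefore shows no sign of stronger inhibition than the hydrogen of compound 1, but the real size of the change stays unknown because the read-out ends at the limit: the limit of > 100000 nM in this assay, at which 2 of the 3 values shown sit.

What the compounds shown leave open is whether this nitrogen tolerates any group at all, since a single substituent cannot separate the effect of the butyl chain from that of the imidazole at its end. A shorter chain ending in an amine or a carboxylic acid, or a simple ethyl group, would help to show whether a number below the limit can be reached with a substituent at this position.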